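Series notes: one-carbon chain extension from compound 2 to compound 3

A few compounds are considered here, and "the series" means these few. Any claim that something is new, unique, unknown or untested is made for them only; others in the source may bear on it.

Values in a functional assay on KB cells (Homo sapiens) for antiproliferative activity, read by MTT assay, with a stated time of 48 h; a lower number here means a stronger inhibitor, a higher number a weaker inhibitor:
compound 1 `Cn1cc(C2=C(c3n[nH]c4ncccc34)C(=O)NC2=O)c2ccccc21`: 62000 nM
compound 2 `Cn1cc(C2=C(c3nn(CCCn4ccnc4)c4ncccc34)C(=O)N(c3ccccc3)C2=O)c2ccccc21`: 6800 nM

Compound 2 gives the lower of the two numbers, and the gap to compound 1 lies beyond the usual scatter. The two compounds differ in several places at once, so no single part of that difference can be assigned a share of the gap.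

Compound 3 `Cn1cc(C2=C(c3nn(CCCCn4ccnc4)c4ncccc34)C(=O)N(c3ccccc3)C2=O)c2ccccc21` is compound 2 with one change: (1H-imidazol-1-yl)methyl in place of 1H-imidazol-1-yl on a saturated chain carbon, three bonds along the chain from an aromatic nitrogen Read one bond further out, the 3-(1H-imidazol-1-yl)propyl chain becomes 4-(1H-imidazol-1-yl)butyl.

Among the compounds with values here, no step of this kind exists among the measured compounds, so the expectation rests on the value of compound 2 alone. The step of a 1.0-fold lower number from compound 2 to compound 3 (0.02 log units; within the scatter) is expected to be small, in either direction, and not beyond the scatter. For compound 3 the estimate in this assay is 6500 nM, with a range from 2500 nM to 17000 nM.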

Compound 3, half-maximal inhibitory concentration: 47300 nM
Beside the measured number, compound 3's estimate is 7.3-fold (0.86 log units) below it; measured number above the stated range.
By their numbers in this assay, from the lowest: compound 2; then compounds 3 and 1 (each within the scatter of the next).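

In this assay, within the data shown here, a single change can now be read for the first time, on a saturated chain carbon, three bonds along the chain from an aromatic nitrogen: a 7.0-fold higher number from compound 2 to compound 3 (0.84 log units; beyond the scatter) is the step from 3-(1H-imidazol-1-yl)propyl to 4-(1H-imidazol-1-yl)butyl. Chain length at this position is therefore not neutral in this assay, at least for this one added carbon with the rest of the structure held fixed. No measurement at hand bears on what lies behind the step.

Going by these compounds, one step gives no trend, so it remains open how a shorter 2-(1H-imidazol-1-yl)ethyl chain or a chain longer than butyl would read. Also open, on these data alone, is whether the 1H-imidazol-1-yl ring itself matters, which a simple amine or a carboxylic acid at the chain end would test.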